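Carboxyalkoxy variants of the prenylated flavonol core

The compounds below may be only part of what the source reports. "The series", "measured", "known", "first", "only" and "open" are said of these compounds alone.

Compound 1 `CCOC(=O)COc1cc(O)c2c(=O)c(O)c(-c3ccc(OC)cc3)oc2c1CC=C(C)C` — 5300 nM
Compound 2 `COc1ccc(-c2oc3c(CC=C(C)C)c(OCCCC(=O)O)cc(O)c3c(=O)c2O)cc1` — 12700 nM
Compound 3 `COc1ccc(-c2oc3c(CC=C(C)C)c(OCCCC(=O)O)cc(O)c3c(=O)c2OCCCC(=O)O)cc1` — 31100 nM

In a functional assay on MDA-MB-435S cells (Homo sapiens) for cytotoxicity, read by MTT assay (on this read-out higher numbers stand for weaker inhibition and lower numbers for stronger inhibition), compound 2 gives 12700 nM, second highest of the three numbers; compound 1 sits lower by a 2.4-fold higher number from compound 1 to compound 2 (0.38 log units; beyond the scatter) and compound 3 higher by a 2.4-fold higher number from compound 2 to compound 3 (0.39 log units; beyond the scatter). Compound 4 `COc1ccc(-c2oc3c(CC=C(C)C)c(OC(C)C(=O)O)cc(O)c3c(=O)c2O)cc1` differs from compound 2 by 1-carboxyethyl in place of 3-carboxypropyl on an oxygen on an aromatic ring. Among the compounds with values here, no measured step shortens or branches the carboxy chain; the two steps seen, each modest and beyond the scatter, concern a different change at the same oxygen and an added 3-carboxypropyl elsewhere. Neither bears directly, so no step beyond the scatter is expected, a 1.1-fold lower number from compound 2 to compound 4 (0.02 log units; within the scatter). Compound 4 is estimated at 12000 nM, range 5000 nM to 30000 nM.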

Compound 4, half-maximal inhibitory concentration: 5700 nM
Beside the measured number, compound 4's estimate is 2.1-fold (0.32 log units) above it; the range from low to high includes it.
By their numbers in this assay, from the lowest: compounds 1 and 4 (each within the scatter of the next); then compound 2; then compound 3.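

Working notes: the chain on this oxygen matters even with the carboxylic acid kept, as this assay shows a 2.2-fold lower number from compound 2 to compound 4 (0.35 log units; beyond the scatter) when 1-carboxyethyl replaces 3-carboxypropyl. The free acid as such does not set the number apart from the ester here, since 1-carboxyethyl in place of (ethoxycarbonyl)methyl gives a 1.1-fold higher number from compound 1 to compound 4 (0.03 log units; within the scatter) and so no change. No measurement available here accounts for the step.

Going by these compounds, the step changes chain length and branching together, so it remains open which of the two counts. On these data alone, an unbranched carboxymethyl on this oxygen would separate them, and how an amine at the chain end would read also remains open.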